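From Compound 2 to Compound 3: Cutting Away One Ring

The source may hold more compounds than are shown below. What is called first, only, known or untested is meant among the compounds shown, and "the series" means these compounds.

The study takes in compound 1 `O=C(CCCc1cn(CCOCCOCCOc2cc(O)c(C(=O)CCc3ccc(O)cc3)c(O)c2)nn1)OCn1cc(F)c(=O)[nH]c1=O`, for which a functional assay on HCT-116 cells (Homo sapiens) for cytotoxicity, read by sulforhodamine B assay, with a stated time of 48 h, in the presence of a further agent that is not named here (on this read-out lower numbers stand for stronger inhibition and higher numbers for weaker inhibition), gives "not determined" (no result reported), so that no number is available for it. Compound 2 `O=C(CCc1ccc(O)cc1)c1c(O)cc(OCCOCCOCCS)cc1O[C@@H]1O[C@H](CO)[C@@H](O)[C@H](O)[C@H]1O` reaches only a limit of the assay in this assay, reported as > 100000 nM. Compound 2 therefore stands at the limit of > 100000 nM in this assay, at which 1 of the 2 values shown sits, the upper edge of what the measurement can report, with the other entry lacking a single number altogether. Compound 3 `O=C(CCc1ccc(O)cc1)c1c(O)cc(OCCOCCOCCS)cc1O` is the unmeasured partner: it differs from compound 2 by hydrogen in place of 3,4,5-trihydroxy-6-(hydroxymethyl)oxan-2-yl on an oxygen on an aromatic ring. Among the measured compounds shown here, no measured pair mirrors this change, so no step from the data can be borrowed. The expectation for the step of an at least 1.6-fold lower number from compound 2 to compound 3 (0.22 log units; that floor lies within the scatter) is one toward stronger inhibition, with the chance that compound 3 also ends at a limit kept in view. Compound 3 is estimated at 60000 nM in this assay, expected between 15000 nM and 250000 nM.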

Compound 3, half-maximal inhibitory concentration: 15900 nM
For compound 3 the middle estimate is 3.8-fold (0.58 log units) above the measured one; measured number inside the range.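

In this assay, replacing the 3,4,5-trihydroxy-6-(hydroxymethyl)oxan-2-yl group on the oxygen on the aromatic ring with hydrogen gives an at least 6.2-fold lower number from compound 2 to compound 3 (0.79 log units; beyond the scatter). Among the compounds shown here, compound 3 thus supplies the first single number in the set, and it shows that this one change at this oxygen is enough to move the read-out off the edge of the assay toward stronger inhibition. The step is only a floor, because compound 2 stands at a limit of the assay and not at a number: the limit of > 100000 nM in this assay, at which 1 of the 3 values shown sits.

On these data alone, whether a small group such as methyl or acetyl on that oxygen would read like compound 3 or like compound 2 remains open. Also open, as far as these compounds go, is what an amine or a carboxylic acid at the end of the chain, in place of the sulfur, would do to the read-out.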